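Aryl versus alkyl on the ring nitrogen: predicting compound 4

The source may hold more compounds than are shown below. What is called first, only, known or untested is meant among the compounds shown, and "the series" means these compounds.

Compound 3 `CCC(CO)N1C(=O)NC2(CC2c2ccc3cccc(OCc4ccccc4)c3n2)C1=O` gives 100 mg/kg in a functional assay on the whole organism (strain Kunming) with Mus musculus as the target, with a stated time of 0.5 h (a higher number here means that more compound is needed for the effect, a lower number that less compound is needed), level with compound 1 `CC(C)N1C(=O)NC2(CC2c2ccc3cccc(OCc4ccccc4)c3n2)C1=O`, which gives 100 mg/kg, and together these are the lowest of the three numbers; compound 2 `O=C1NC2(CC2c2ccc3cccc(OCc4ccccc4)c3n2)C(=O)N1c1cc(Cl)cc(Cl)c1` gives 300 mg/kg. The relevant steps are no change at the digits printed from compound 1 to compound 3 (within the scatter) and a 3.0-fold lower number from compound 2 to compound 3 (0.48 log units; beyond the scatter). Compound 4 `COc1ccc(N2C(=O)NC3(CC3c3ccc4cccc(OCc5ccccc5)c4n3)C2=O)cc1` differs from compound 3 by 4-methoxyphenyl in place of 1-(hydroxymethyl)propyl on an amide-type nitrogen in a ring. The only earlier switch from an alkyl to an aryl group on that nitrogen, a 3.0-fold higher number from compound 1 to compound 2 (0.48 log units; beyond the scatter), raised the number modestly, while the alkyl-to-alkyl step gave no change. A modest rise beyond the scatter is therefore expected, a 3.0-fold higher number from compound 3 to compound 4 (0.48 log units; beyond the scatter). Compound 4 is estimated at 300 mg/kg, with a range from 100 mg/kg to 1000 mg/kg.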

Compound 4, minimum effective dose: 300 mg/kg
Estimate against measurement, compound 4: no gap at the digits printed, and the stated range covers the measured number.
By their numbers in this assay, from the lowest: compounds 1 and 3 (each within the scatter of the next); then compounds 2 and 4 (each within the scatter of the next).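

With 4-methoxyphenyl, the rise seen with the first aryl group recurs in this assay as a 3.0-fold higher number from compound 3 to compound 4 (0.48 log units; beyond the scatter) and as a 3.0-fold higher number from compound 1 to compound 4 (0.48 log units; beyond the scatter) in the same comparison with the two alkyl groups. The two aryl groups are not told apart at this position, with no change at the digits printed from compound 2 to compound 4 (within the scatter) despite their different substituents, so among these four compounds both aryl groups stand apart from both alkyl groups, and none goes against this. No measured evidence accounts for this difference. The compounds shown leave open whether unsubstituted phenyl or a phenyl ring bearing an amine or a carboxylic acid would follow the same pattern. They also leave open how a longer alkyl chain on this nitrogen would compare.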